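Estimating compound 4 after loss of the trifluoromethyl group

A few compounds are considered here, and "the series" means these few. Any claim that something is new, unique, unknown or untested is made for them only; others in the source may bear on it.

Values in an ADME assay on Vero cells (Chlorocebus sabaeus) for cytotoxicity, read by MTT assay (on this read-out lower numbers stand for higher toxicity in this test and higher numbers for lower toxicity in this test), follow.
Compound 1 `Cn1nc(C(F)(F)F)cc1C(=O)Nc1ccc(S(=O)(=O)N2CCCCC2)cc1` gives > 300000 nM (a limit)
Compound 2 `Cn1nc(C(F)(F)F)cc1C(=O)Nc1ccc(S(=O)(=O)N2CCCCCC2)cc1` gives > 300000 nM (a limit)
Compound 3 `Cn1nc(C(F)(F)F)cc1C(=O)Nc1ccc(S(=O)(=O)N2CCC(C(F)(F)F)CC2)cc1` gives 159000 nM (a number)

Compound 3 alone holds a number, while compound 1 and compound 2 rest on the limit of > 300000 nM in this assay, at which 2 of the 3 values shown sit, in this series. The change to compound 4 `Cn1nc(C(F)(F)F)cc1C(=O)Nc1ccc(S(=O)(=O)N2CCC(NC(=O)OC(C)(C)C)CC2)cc1` is (tert-butoxycarbonyl)amino in place of trifluoromethyl on a saturated ring carbon and sits three ring bonds from the ring nitrogen. For the measured compounds named here, two measured steps bear on it, since both bring in the trifluoromethyl group that now leaves. These are an at least 1.8-fold lower number from compound 1 to compound 3 (0.27 log units; that floor lies within the scatter) and an at least 1.8-fold lower number from compound 2 to compound 3 (0.27 log units; that floor lies within the scatter) in size. The remaining step, a step that the two limits leave unreadable from compound 1 to compound 2, adds nothing readable. Going by the values given here, no measured compound carries the entering group. With compound 3 at 159000 nM and both floors within the scatter, the change expected in this assay is small, at most a slight rise. The expected move is a 1.4-fold higher number from compound 3 to compound 4 (0.14 log units; within the scatter) and so stays within the scatter. For compound 4 the estimated value is 220000 nM with an expected range from 100000 nM to 450000 nM in all. The assay may also report only a limit for it.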

Compound 4, half-maximal cytotoxic concentration: > 300000 nM
Compound 4: a limit, no number; the forecaster's own chance of this, stated with the estimate: 45%; middle value at least 1.3-fold (0.13 log units) from the limit.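

In this assay, replacing trifluoromethyl with (tert-butoxycarbonyl)amino on this saturated ring carbon gives an at least 1.8-fold higher number from compound 3 to compound 4 (0.27 log units; that floor lies within the scatter), so this floor does not separate the two groups. The position therefore takes an entering group with more heavy atoms, a hydrogen-bond donor and hydrogen-bond acceptors, yet the result is still no number, and the step from compound 1 to compound 4 cannot be read because both ends are limits. The value of compound 4 is a limit, and it joins the series' ceiling: the limit of > 300000 nM in this assay, at which 3 of the 4 values shown sit.

Compound 3 alone holds a number, so whether trifluoromethyl truly lowers the read-out remains unsettled. From the compounds shown here alone, how a free amine or a carboxylic acid on this ring carbon would read in this assay also stays open.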